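The compounds below may be only part of what the source reports. "The series", "measured", "known", "first", "only" and "open" are said of these compounds alone.

Measured compounds:
compound 1, `CN(C)c1ccc(C(=O)Nc2cccc(NC(=O)COc3ccc4c(c3)CCC(=O)N4)c2)cc1` — 9970 nM
compound 2, `CCOc1ccc(C(=O)Nc2cccc(NC(=O)COc3ccc4c(=O)ccoc4c3)c2)cc1` — 9 nM

In an assay on isolated protein for inhibition of Rho-associated protein kinase 2 (Homo sapiens), read by scintillation counting, radiometric assay and 33P incorporation, with a stated time of 40 min, in the presence of a further agent that is not named here (on this read-out lower numbers stand for stronger inhibition and higher numbers for weaker inhibition), compound 2 gives the lower of the two numbers; compound 1 stands far higher, and the gap between them lies beyond the usual scatter. Within the data shown here, the two differ in several places at once, so no single step connects them.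

Compound 3 is `Nc1ccc(C(=O)Nc2cccc(NC(=O)COc3ccc4c(=O)ccoc4c3)c2)cc1`, not yet measured. It follows from compound 2 by one change: amino in place of ethoxy on an aromatic carbon. Ethoxy leaves and amino enters on the same aromatic carbon. Among the measured compounds shown here, no measured pair isolates this change, so there is no directly comparable step to draw on.

The expected step of a 2.2-fold higher number from compound 2 to compound 3 (0.35 log units; beyond the scatter) is a small one toward a higher number, likely within the scatter. The basis is thin: compound 2 gives 9 nM with ethoxy in that position, and compound 1 offers no clean control. Compound 3 is estimated at 20 nM, with a range from 5 nM to 100 nM.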

Compound 3, half-maximal inhibitory concentration: 83 nM
Compound 3: the middle estimate sits 4.2-fold (0.62 log units) below what was measured; the range from low to high includes it.
By their numbers in this assay, from the lowest: compound 2; then compound 3; then compound 1.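

In this assay, amino in place of ethoxy on the aromatic carbon para to a large group gives a 9.2-fold higher number from compound 2 to compound 3 (0.96 log units; beyond the scatter), so this position responds to the group it carries. The change weakens inhibition without abolishing it, as compound 3 still gives 83 nM. No measurement available here accounts for the size of this step.

The change swaps ethoxy, with 3 heavy atoms and no hydrogen-bond donor, for amino, with 1 heavy atom and 1 hydrogen-bond donor, and the compounds shown do not separate these two differences. Methoxy, hydroxyl or a longer alkoxy chain such as propoxy on the same carbon would bear on this, and how far the position tolerates a carboxylic acid also remains open.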